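Fluoro-to-methyl swap on the benzamide ring, compound 3

This account rests on a few compounds, and the source may have more. Where it says the series, first, only, none or still open, it means among the compounds named here.

Among the measured compounds shown here, compound 1 `Cc1cc(C(=O)O)cc(C)c1NC(=O)c1cc(-c2cccc(CO)c2)ccc1F` is the stronger of the two measured members. In a functional assay on HEK293 cells for antagonist activity at prostaglandin E2 receptor EP4 subtype (Homo sapiens), read by HTRF and cAMP accumulation, with a stated time of 1 h (on this read-out lower numbers stand for stronger inhibition and higher numbers for weaker inhibition), compound 1 gives 0.73 nM. For the measured compounds named here, its only measured neighbour, compound 2 `Cc1ccc(C(=O)O)c(C)c1NC(=O)c1cc(-c2cccc(CO)c2)ccc1F`, gives 4.49 nM in this assay, a weaker result that lies beyond the scatter, so compound 1 holds the lowest number on record.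

Compound 3 `Cc1ccc(-c2cccc(CO)c2)cc1C(=O)Nc1c(C)cc(C(=O)O)cc1C` has not yet been measured. It differs from compound 1 in one place: methyl in place of fluoro on an aromatic carbon, a methyl in place of fluoro on an aromatic carbon, ortho to a large group and para to the 3-(hydroxymethyl)phenyl group. Going by the values given here, no measured pair isolates this exchange, so the direction of the step is open. The expected step from compound 1 to compound 3 in this assay is a 2.1-fold higher number from compound 1 to compound 3 (0.31 log units; beyond the scatter), a slight weakening that may well remain within the scatter. Compound 3 is estimated at 1.5 nM, with a range from 0.4 nM to 6 nM.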

Compound 3, half-maximal inhibitory concentration in the prostaglandin E2 receptor EP4 subtype assay: 0.28 nM
Estimate against measurement, compound 3: 5.4-fold (0.73 log units) above; the whole stated range lies above it.
By their numbers in the prostaglandin E2 receptor EP4 subtype assay, from the lowest: compound 3; then compound 1; then compound 2.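

In the prostaglandin E2 receptor EP4 subtype assay, methyl in place of fluoro gives a 2.6-fold lower number from compound 1 to compound 3 (0.42 log units; beyond the scatter), the first step read at this position. This aromatic carbon, ortho to a large group and para to the 3-(hydroxymethyl)phenyl group, therefore accepts a methyl, and an exchange of one heavy atom with no change in hydrogen-bond donors or acceptors is enough to move the number beyond the scatter. The same exchange carries a much larger step in the opposite sense for the compound's profile, a loss of solubility in a physicochemical assay for solubility, read by HPLC, with a stated time of 20 h, at pH 6; on this read-out higher numbers stand for higher solubility and lower numbers for lower solubility: the measured solubility of compound 1, 774 ug/mL, and of compound 3, 31 ug/mL, a 25-fold lower number (1.40 log units; beyond the scatter) In the physicochemical assay compound 1 gives 774 ug/mL and compound 3 gives 31 ug/mL.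

A single pair cannot tell whether the lower inhibition number and the lower solubility must travel together at this position. A chloro, methoxy or ethyl group on the same aromatic carbon would show whether the two read-outs can be separated.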